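The source may report more compounds than this note shows. Statements on the series, on what has been measured and on what is new or still open speak of the compounds shown alone.

Measured so far in a functional assay on CHO cells for agonist activity at Free fatty acid receptor 1 (Homo sapiens), read by FLIPR, tested at 100 nM; on this read-out lower numbers stand for a weaker effect and higher numbers for a stronger effect at the one concentration tested:
compound 1 `Cc1cccc(OCC(=O)Nc2ccc(OCC(=O)O)c(F)c2)c1` gives 45.4%
compound 2 `CC(C)c1cccc(OCC(=O)Nc2ccc(OCC(=O)O)c(F)c2)c1` gives 43.3%

Among the measured compounds shown here, compound 2 has compound 1 as its only neighbour, and the two numbers sit within the usual scatter of each other, so they cannot be told apart: the step of a number 2.1 percentage points lower from compound 1 to compound 2 (within the scatter) counts as no real change.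

Compound 3 `CC(C)(C)c1cccc(OCC(=O)Nc2ccc(OCC(=O)O)c(F)c2)c1` is not yet measured. It differs from compound 2 by methyl in place of hydrogen on a saturated chain carbon bound to an aromatic carbon and two saturated chain carbons.

For the measured compounds named here, the one measured step that speaks to this change is the earlier growth of the same group, from methyl to isopropyl, and that step, a number 2.1 percentage points lower from compound 1 to compound 2 (within the scatter), stayed within the scatter. Going one carbon further, from isopropyl to tert-butyl, is therefore expected to give no step beyond the scatter in this assay, in either direction.

For compound 3 the expected value in this assay is 42%, with a range from 30% to 55%, which means an expected step of a number 1.3 percentage points lower from compound 2 to compound 3 (within the scatter).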

Compound 3, a percentage reported as activity, at one concentration (the size of the read-out at that concentration, not a potency): 40.2%
Compound 3: middle estimate off by 1.8 percentage points, on the high side; the measured number falls inside the stated range.
By their numbers in this assay, from the lowest: compounds 3, 2 and 1 (each within the scatter of the next).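

In this assay, the added methyl that turns isopropyl into tert-butyl gives a number 3.1 percentage points lower from compound 2 to compound 3 (within the scatter), and the full change from the smallest group to the most branched gives a number 5.2 percentage points lower from compound 1 to compound 3 (within the scatter). The earlier pair covered only the change from methyl to isopropyl; this result extends the flat picture to tert-butyl, so methyl, isopropyl and tert-butyl on this aromatic carbon cannot be told apart at the one concentration tested. No supporting data are available to explain this absence of a measurable change.

The compounds shown leave open whether a group of a different kind here, such as an amine, a methoxy group or a carboxylic acid, would move the number beyond the scatter. The read-out comes from a single concentration, so they also leave open whether these three compounds would show a stronger or weaker effect than one another at any other concentration.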